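Swapping Methyl for Methoxy on the Shared Core

The compounds below may be only part of what the source reports. "The series", "measured", "known", "first", "only" and "open" are said of these compounds alone.

Of the compounds shown here, three built on one shared core have been measured in an assay on isolated protein for inhibition of DNA topoisomerase 1 (Homo sapiens), with a stated time of 30 min, tested at 20 uM; on this read-out higher numbers stand for a stronger effect at the one concentration tested and lower numbers for a weaker effect. Compound 1 `Cc1cccc(-c2nc3ccc(C)cc3c(=O)[nH]2)c1` gives 12.7% in this assay, the highest of the three numbers, and it stands beyond the scatter above the other two. Compound 2 `CCN(CC)c1ccc2nc(-c3ccccc3OC(F)(F)F)[nH]c(=O)c2c1` gives 0% in this assay, and compound 3 `Cc1ccc2c(=O)[nH]c(-c3ccccc3F)nc2c1` gives 0%. Compounds 2 and 3 therefore show no measurable inhibition at the tested concentration, whereas compound 1 shows a modest one.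

Compound 4 `COc1cccc(-c2nc3ccc(C)cc3c(=O)[nH]2)c1` has not yet been measured. It differs from compound 1 in a single place: methoxy in place of methyl on an aromatic carbon. Within the data shown here, no pair of measured compounds differing in just one place is available to show how such a change plays out on this core, so the forecast rests only on the small size of the change and on the modest read-out of compound 1 at 12.7%. A step no larger than the scatter is expected, in either direction. The value expected for compound 4 is therefore 10%, with a range from 0% to 28%. The expected change is a number 2.7 percentage points lower from compound 1 to compound 4 (within the scatter).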

Compound 4, a percentage reported as inhibition, at one concentration (the size of the read-out at that concentration, not a potency): 0%
The estimate for compound 4 lay 10 percentage points above the measured number; the measured number falls inside the stated range.
By their numbers in this assay, from the lowest: compounds 2, 3 and 4 (each within the scatter of the next); then compound 1.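

In this assay, among these compounds, the swap of methyl for methoxy on an aromatic carbon, meta to a large group, brings a number 12.7 percentage points lower from compound 1 to compound 4 (beyond the scatter) and gives the first single-place step on the shared core. This shows that a change of this size at this position is enough to remove the modest inhibition seen for compound 1, leaving compound 4 at 0% at the one concentration tested. The data shown offer no measured basis for explaining this loss.

Still open, going by these compounds, is whether the loss is specific to methoxy or would also follow from other groups at this position, such as a hydroxyl, an ethyl or an amine. A plain hydrogen in the same place would show whether the methyl of compound 1 contributes to its inhibition at all.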